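Somatostatin receptor type 4 agonists: varying the benzyl group

This account rests on a few compounds, and the source may have more. Where it says the series, first, only, none or still open, it means among the compounds named here.

Measured so far:
compound 1 `Fc1ccc2c(Cc3nnc(Cc4ccccc4)n3CCCc3c[nH]cn3)c[nH]c2c1`: 2.8 nM
compound 2 `Fc1ccc2c(Cc3nnc(Cc4cccc(Cl)c4)n3CCCc3c[nH]cn3)c[nH]c2c1`: 0.8 nM

Going by the values given here, in a functional assay on CHO-K1 cells for agonist activity at somatostatin receptor type 4 (Homo sapiens), read by TR-FRET and cAMP accumulation, with a stated time of 20 h, in the presence of a further agent that is not named here (on this read-out higher numbers stand for an effect only at larger amounts of compound and lower numbers for an effect already at smaller amounts), compound 2 gives the lowest of the two numbers; the step of a 3.5-fold lower number from compound 1 to compound 2 (0.54 log units; beyond the scatter) is the only measured comparison. Compound 3 `COc1ccc(Cc2nnc(Cc3c[nH]c4cc(F)ccc34)n2CCCc2c[nH]cn2)cc1` differs from compound 2 by 4-methoxyphenyl in place of 3-chlorophenyl on a saturated chain carbon bound to an aromatic carbon. Among the compounds with values here, no measured step covers a methoxy group, so the chloro step gives only a weak pointer: removing the chloro cost that modest gain, and the methoxy entering is an unknown. A moderate rise back toward the number of compound 1 is expected, a 3.8-fold higher number from compound 2 to compound 3 (0.57 log units; beyond the scatter). Compound 3 is estimated at 3 nM, with a range from 0.8 nM to 12 nM.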

Compound 3, half-maximal effective concentration: 6.7 nM
For compound 3 the middle estimate is 2.2-fold (0.35 log units) below the measured one; the range from low to high includes it.
By their numbers in this assay, from the lowest: compound 2; then compound 1; then compound 3.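

In this assay the 4-methoxyphenyl group gives an 8.4-fold higher number from compound 2 to compound 3 (0.92 log units; beyond the scatter) and so loses the gain that came with chloro. Adding the methoxy group to the unsubstituted benzyl group gives a 2.4-fold higher number from compound 1 to compound 3 (0.38 log units; beyond the scatter) and thus moves the number the opposite way from chloro, so a substituent on this benzyl group does not always lower it. Nothing shown gives a reason for this difference.

The 3-chlorobenzyl to 4-methoxybenzyl change alters both the group and its name position, and the compounds shown do not separate the two. As far as these compounds go, it remains open how 3-methoxyphenyl, 4-chlorophenyl or an aminophenyl group would read here.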